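This account rests on a few compounds, and the source may have more. Where it says the series, first, only, none or still open, it means among the compounds named here.

Compound 1, `CCNc1nc(-c2ccccc2)nc2c1nnn2Cc1ccccc1Cl`, is the starting point. In an assay on isolated protein for binding affinity to adenosine receptor A1 (Bos taurus) (a higher number here means a weaker inhibitor, a lower number a stronger inhibitor), compound 1 gives 463000000 nM, the highest of the three numbers recorded here. Compound 2, `CNc1nc(-c2ccccc2)nc2c1nnn2Cc1ccccc1F`, gives 25000000 nM in this assay, and compound 3, `CCCCNc1nc(-c2ccccc2)nc2c1nnn2Cc1ccccc1`, gives 11000000 nM. Each of these two differs from compound 1 in more than one place, so they show only where their own numbers fall, which is below that of compound 1 and beyond the scatter in both cases. Compound 4, `Clc1ccccc1Cn1nnc2c(NC3CC3)nc(-c3ccccc3)nc21`, has not yet been measured. It differs from compound 1 by cyclopropyl in place of ethyl on a nitrogen on an aromatic ring. Among the measured compounds shown here, no measured pair shows this change on its own, so the size of its step is not known from the data. The step of a 2.3-fold lower number from compound 1 to compound 4 (0.36 log units; beyond the scatter) is expected to be a modest move toward a lower number, not clearly beyond the scatter. Compound 4 is therefore expected to give about 200000000 nM in this assay, with a range from 50000000 nM to 1000000000 nM.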

Compound 4, inhibition constant: 11000000 nM
For compound 4 the middle estimate is 18-fold (1.26 log units) above the measured one; the whole stated range lies above it.
By their numbers in this assay, from the lowest: compounds 3 and 4 (each within the scatter of the next); then compound 2; then compound 1.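

Among the compounds shown here, this is the first change in the set that can be read on its own: with the rest of compound 1 held fixed, ethylamino gives way to cyclopropylamino, and this assay shows a 42-fold lower number from compound 1 to compound 4 (1.62 log units; beyond the scatter). The group on this nitrogen therefore matters a great deal, since a swap of a small carbon group alone moves the number by a large step, well beyond the scatter. Nothing on record accounts for the size of this step.

As far as these compounds go, it remains open whether the ring or the added carbon carries the effect, and an isopropyl or a cyclobutyl group on the same nitrogen, with the rest of compound 1 unchanged, would help separate the two. From the compounds shown here alone, it is also open whether the same swap gives a similar step when the chlorine of compound 1 is replaced by another group, such as a methoxy group.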